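The source may report more compounds than this note shows. Statements on the series, on what has been measured and on what is new or still open speak of the compounds shown alone.

In a functional assay on MCF7 cells (Homo sapiens) for inhibition, read by MTT assay, with stated times of 18 h and 4 h (a higher number here means a weaker inhibitor, a lower number a stronger inhibitor), compound 1 `CCCCCCCCCCCCCCCCOP(=O)(O)OCCSC(=S)N1CCCCCC1` gives > 100000 nM as its result, and that is a limit, not a number. Compound 2 `CCCCCCCCCCCCCCCCOP(=O)(O)OCCSC(=S)N1CCN(C)CC1` gives > 100000 nM as its result, again a limit. Compound 1 therefore stands at the limit of > 100000 nM in this assay, at which 2 of the 3 values shown sit, and has no exact position on the scale. Compound 3 `CCCCCCCCCCOP(=O)(O)OCCSC(=S)N1CCCCC1` reads 7240 nM and is the only one of the three with a true number.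

Compound 4 `CCCCCCOP(=O)(O)OCCSC(=S)N1CCCCCC1` differs from compound 1 in one place, with hydrogen in place of decyl on a saturated chain carbon, six bonds along the chain from an oxygen on an unsaturated carbon as the change, so hydrogen stands in place of decyl on a saturated chain carbon, six bonds along the chain from an oxygen on an unsaturated carbon.

Among the compounds with values here, the one measured step, a step that the two limits leave unreadable from compound 1 to compound 2, has no size to borrow and concerns the group on the thiocarbonyl carbon, not the chain. That leaves compound 3 at 7240 nM as a rough anchor. The expected step is an at least 2.5-fold lower number from compound 1 to compound 4 (0.39 log units; beyond the scatter) toward a stronger inhibitor, although a result that stays at the limit is about as likely. For compound 4 the estimate is 40000 nM with an expected range from 8000 nM to 100000 nM.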

Compound 4, half-maximal inhibitory concentration: 55000 nM
Estimate against measurement, compound 4: 1.4-fold (0.14 log units) below, and the stated range covers the measured number.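

Within the data shown here, putting hydrogen in place of decyl on this saturated chain carbon gives an at least 1.8-fold lower number from compound 1 to compound 4 (0.25 log units; that floor lies within the scatter) in this assay, the first step in the chain that can be read at all. Among these compounds, compound 4 has a true number on the scale, so this chain position can change the result, whereas the only earlier step concerned the group on the thiocarbonyl carbon and could not be read. The full size of the step stays unknown, and it may be no larger than the usual scatter, because compound 1 has only a limit: the limit of > 100000 nM in this assay, at which 2 of the 4 values shown sit.

The compounds shown leave open how the number moves with other chains in this place, such as octyl or dodecyl, on the same azepan-1-yl group. They also leave open what an amine or a carboxylic acid on the chain would do.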